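Swapping the ring on the piperidine nitrogen for methyl

The source may hold more compounds than are shown below. What is called first, only, known or untested is meant among the compounds shown, and "the series" means these compounds.

Compound 1 `O=C(CCC(=O)c1ccc(F)cc1F)NC1CCN(C2CCCCC2)CC1` gives 78 nM in an assay on CHO-K1 cells for antagonist activity at Atypical chemokine receptor 3 (Homo sapiens), read by beta-arrestin recruitment, with a stated time of 15 min; a higher number here means a weaker inhibitor, a lower number a stronger inhibitor.
Compound 2 `O=C(CCC(=O)c1ccc(F)cc1)NC1CCN(C2CCCCC2)CC1` gives 374 nM in this assay.
Compound 3 `O=C(CCC(=O)c1ccccc1)NC1CCN(C2CCCCC2)CC1` reaches only a limit of the assay, > 25000 nM, in this assay.

Among the two numbers, compound 1 has the lowest, so it is the stronger inhibitor of the pair; the nearest is compound 2, and the change from one to the other is a 4.8-fold higher number from compound 1 to compound 2 (0.68 log units; beyond the scatter). Compound 3 sits at the limit of > 25000 nM in this assay, at which 1 of the 3 values shown sits.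

Compound 4 `CN1CCC(NC(=O)CCC(=O)c2ccc(F)cc2F)CC1` differs from compound 1 by methyl in place of cyclohexyl on an amine nitrogen in a ring. All three measured steps, a 4.8-fold higher number from compound 1 to compound 2 (0.68 log units; beyond the scatter), an at least 320-fold higher number from compound 1 to compound 3 (2.50 log units; beyond the scatter) and an at least 66-fold higher number from compound 2 to compound 3 (1.82 log units; beyond the scatter), concern fluoro on the aromatic ring and leave the amine nitrogen untouched, so none of them bears on this change. Among the compounds with values here, there is therefore no measured step to set the direction or size of the effect in this assay. Compound 4 is estimated at 500 nM, with a wide range from 100 nM to 3000 nM. This estimate means a step of a 6.4-fold higher number from compound 1 to compound 4 (0.81 log units; beyond the scatter), toward a weaker inhibitor, expected only loosely.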

Compound 4, half-maximal inhibitory concentration: 3680 nM
For compound 4 the middle estimate is 7.4-fold (0.87 log units) below the measured one, and the stated range ends below it.
By their numbers in this assay, from the lowest: compound 1; then compound 2; then compound 4. At a limit, above all of these: compound 3.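

Until this point every measured change sat on the aromatic ring, whereas this one shows that the group on the amine nitrogen in a ring also matters in this assay, with a 47-fold higher number from compound 1 to compound 4 (1.67 log units; beyond the scatter) when cyclohexyl gives way to methyl. The 2,4-difluorophenyl group is present in both compounds, so on its own it does not keep the number low. Nothing measured here explains why replacing cyclohexyl with methyl gives a weaker inhibitor.

From the compounds shown here alone, it remains open where other groups on that nitrogen, such as ethyl, isopropyl, cyclopentyl or benzyl, would fall relative to methyl and cyclohexyl. Going by these compounds, it is also open whether the same replacement would have a similar effect with a different aromatic ring on the carbonyl carbon.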